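Swapping acetyl for cyano on a chromene core

The compounds below may be only part of what the source reports. "The series", "measured", "known", "first", "only" and "open" are said of these compounds alone.

The study measures how strongly compounds relax rat aortic tissue in a functional assay (aorta) with Rattus norvegicus as the target; a lower number here means a less potent compound, a higher number a more potent compound, by a factor of ten per unit of this negative logarithm. Compound 1 `CC(=O)c1ccc2c(c1)C(n1ccccc1=O)=CC(C)(C)O2` stands highest of the two measured compounds: in this assay compound 1 gives 7.37. Compound 2 `CC1(C)C=C(n2ccccc2=O)c2cc(OC(=O)Nc3ccccc3C(F)(F)F)ccc2O1` is the other measured compound, and in this assay compound 2 gives 5.58, a gap beyond the usual scatter. Compound 3 `CC1(C)C=C(n2ccccc2=O)c2cc(C#N)ccc2O1` has not yet been measured; it differs from compound 1 by cyano in place of acetyl on an aromatic carbon. Among the measured compounds shown here, no step between two measured compounds shows how this change acts, so only a modest step is expected from compound 1 to compound 3 in this assay, a number 0.23 log units higher from compound 1 to compound 3 (within the scatter), upward if anything. Compound 3 is therefore estimated to give 7.6, within 7 to 8.2.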

Compound 3, logarithm of the reciprocal of the active concentration, log(1/C): 7.67
Estimate against measurement, compound 3: 0.07 log units below; the range from low to high includes it.
By their numbers in this assay, from the lowest: compound 2; then compounds 1 and 3 (each within the scatter of the next).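

In this assay, among the compounds shown here, the exchange on this aromatic carbon gives a number 0.30 log units higher from compound 1 to compound 3 (within the scatter), the first reading of a single change at this place on the shared core. Acetyl is therefore not required here, since cyano in its place leaves the two compounds indistinguishable in this tissue assay. Nothing measured explains this match. From the compounds shown here alone, whether an amine, a carboxylic acid or a longer chain on the same carbon would also hold the activity remains open. So does whether the match between acetyl and cyano extends beyond this one pair.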